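The source may report more compounds than this note shows. Statements on the series, on what has been measured and on what is new or still open speak of the compounds shown alone.

Among the measured compounds shown here, the three compounds measured so far share one core and differ only in the group on the oxygen next to the carbonyl group. Compound 1 `COc1ccc(OC(=O)c2cn(-c3ccccc3)nc2-c2ccncc2)cc1` carries a 4-methoxyphenyl there. In a functional assay on Raji cells (Homo sapiens) for cytotoxicity, read by MTT assay, with a stated time of 48 h (a lower number here means a stronger inhibitor, a higher number a weaker inhibitor), compound 1 gives only a limit, > 100000 nM (the limit of > 100000 nM in this assay, at which 1 of the 3 values shown sits). Compound 2 `CC(C)(C)c1ccc(OC(=O)c2cn(-c3ccccc3)nc2-c2ccncc2)cc1` carries a 4-(tert-butyl)phenyl, and in this assay compound 2 gives 33300 nM. Compound 3 `Cc1ccc(C(C)C)c(OC(=O)c2cn(-c3ccccc3)nc2-c2ccncc2)c1` carries a 2-isopropyl-5-methylphenyl, and in this assay compound 3 gives 10600 nM, the lowest of the two numbers; the steps of an at least 3.0-fold lower number from compound 1 to compound 2 (0.47 log units; beyond the scatter) and a 3.1-fold lower number from compound 2 to compound 3 (0.50 log units; beyond the scatter) both run downward.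

Compound 4 `O=C(O)c1cn(-c2ccccc2)nc1-c1ccncc1` removes the aryl group entirely: hydrogen in place of 2-isopropyl-5-methylphenyl on an oxygen next to a carbonyl group. For the measured compounds named here, no measured step removes the aryl group; the measured steps only swap one aryl for another, and each lowered the number. Taking the aryl away altogether is expected to go the other way and raise the number, probably past what the assay can report. The expected step is a 9.4-fold higher number from compound 3 to compound 4 (0.97 log units; beyond the scatter). Compound 4 is therefore estimated at about 100000 nM, within 30000 nM to 300000 nM, with a real chance that only a limit is returned.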

Compound 4, half-maximal inhibitory concentration: > 100000 nM
Compound 4: a limit, no number; the forecaster's own chance of this, stated with the estimate: 60%; the middle value sits exactly at the limit.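

Until now this position had only held one aryl group or another, and hydrogen there shows what happens with no aryl group at all: the change gives an at least 9.4-fold higher number from compound 3 to compound 4 (0.97 log units; beyond the scatter) and an at least 3.0-fold higher number from compound 2 to compound 4 (0.47 log units; beyond the scatter). Compound 4 gives only a limit rather than a number, so both steps are minimum sizes and the true loss could be larger. Compound 1 also stops at a limit, so the step between compound 1 and compound 4 cannot be read, and an aryl group alone clearly does not ensure a measurable number: the limit of > 100000 nM in this assay, at which 2 of the 4 values shown sit.

As far as these compounds go, it stays open how an amide formed with an amine, or an ester carrying a longer alkyl chain, would read in this assay. From the compounds shown here alone, it also stays open whether any group here could bring the number far below that of compound 3, 10600 nM.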